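A few compounds are considered here, and "the series" means these few. Any claim that something is new, unique, unknown or untested is made for them only; others in the source may bear on it.

Two compounds of the series carry a number in a functional assay on HepG2 cells (Homo sapiens) for cytotoxicity, read by sulforhodamine B assay, with a stated time of 48 h; on this read-out lower numbers stand for stronger inhibition and higher numbers for weaker inhibition. Compound 1 `CCOC(=O)c1c(-c2ccco2)c(C#N)c(=O)n(/N=C(\C)c2ccc(NS(=O)(=O)c3ccc(Cl)cc3)cc2)c1N` gives 10300 nM in this assay, and compound 2 `CCOC(=O)c1c(-c2ccc(Cl)cc2)c(C#N)c(=O)n(/N=C(\C)c2ccc(NS(=O)(=O)c3ccc(Cl)cc3)cc2)c1N` gives 20200 nM. Among the measured compounds shown here, the only step between measured compounds that differ in one place is a 2.0-fold higher number from compound 1 to compound 2 (0.29 log units; within the scatter), so compound 2 holds the highest of the two numbers, with compound 1 as its nearest neighbour at a distance that stays within the scatter; no order between the two can be read from this.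

Compound 3 `CCOC(=O)c1c(-c2ccc([N+](=O)[O-])cc2)c(C#N)c(=O)n(/N=C(\C)c2ccc(NS(=O)(=O)c3ccc(Cl)cc3)cc2)c1N` is not yet measured. It differs from compound 2 in one place: nitro in place of chloro on an aromatic carbon. For the measured compounds named here, no measured step exchanges one substituent for another on that ring; the single known step swaps the whole ring and stays within the scatter. There is thus no basis in the series for a step beyond the scatter in this assay in either direction, and the uncertainty is correspondingly wide. For compound 3 the expected step from compound 2 is a 1.0-fold lower number from compound 2 to compound 3 (0.00 log units; within the scatter). The estimate for compound 3 in this assay is therefore 20000 nM, with a range from 7000 nM to 60000 nM.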

Compound 3, half-maximal inhibitory concentration: 41100 nM
Estimate against measurement, compound 3: 2.1-fold (0.31 log units) below, and the stated range covers the measured number.
By their numbers in this assay, from the lowest: compounds 1 and 2 (each within the scatter of the next); then compound 3.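

In this assay the carbon para to a large group on the six-membered aromatic ring now gives the series its first step beyond the scatter: exchanging chloro for nitro produces a 2.0-fold higher number from compound 2 to compound 3 (0.31 log units; beyond the scatter) and so shows that the substituent on this ring can shift the number, if only modestly, whereas the earlier ring swap stayed within the scatter. Against the furan-2-yl compound, the 4-nitrophenyl group gives a 4.0-fold higher number from compound 1 to compound 3 (0.60 log units; beyond the scatter) and compound 3 is the weakest of the three, with its steps to both other compounds beyond the scatter. No available data bear on why the nitro compound gives the higher number.

From the compounds shown here alone, with only chloro and nitro compared at this ring carbon, it remains open whether the shift is specific to nitro or would also appear with an amine, a carboxylic acid or a methoxy group there. The ethyl ester, the nitrile and the 4-chlorophenyl sulfonamide are the same in all three compounds, so their contribution to the numbers in this assay cannot be judged from this set.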